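The source may report more compounds than this note shows. Statements on the series, on what has been measured and on what is new or still open speak of the compounds shown alone.

In a functional assay on PC-3 cells (Homo sapiens) for antiproliferative activity, read by MTT assay, with a stated time of 96 h (a higher number here means a weaker inhibitor, a lower number a stronger inhibitor), compound 1 `CC(C)(C)OC(=O)N1CCC(CNc2ccc3nnnc(Nc4cccc(OC(F)(F)F)c4)c3n2)CC1` returns > 100000 nM, which is a limit of the assay and not a number. Its true position is therefore open on the weak side. Going by the values given here, compound 2 `CC(C)N1CCN(c2ccc3nnnc(Nc4cccc(OC(F)(F)F)c4)c3n2)CC1` gives 13800 nM in this assay, the only actual number so far.

Compound 3 `FC(F)(F)Oc1cccc(Nc2nnnc3ccc(NCC4CCNCC4)nc23)c1` is derived from compound 1 by one change, with hydrogen in place of tert-butoxycarbonyl on an amine nitrogen in a ring, the six-membered non-aromatic ring with 1 nitrogen: hydrogen in place of tert-butoxycarbonyl on an amine nitrogen in a ring. Among the compounds with values here, no step between measured compounds is available to size this change, so the expectation rests on little.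

The value of compound 2 of 13800 nM shows that a number can be reached in this assay. On that basis compound 3 is expected to read as a stronger inhibitor than the limit of compound 1, by a step beyond the usual scatter. The expected change is an at least 5.0-fold lower number from compound 1 to compound 3 (0.69 log units; beyond the scatter). For compound 3 the estimated half-maximal inhibitory concentration is 20000 nM, with an expected range from 6000 nM to 70000 nM.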

Compound 3, half-maximal inhibitory concentration: 8320 nM
Compound 3: the middle estimate sits 2.4-fold (0.38 log units) above what was measured, within the range that was stated.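

In this assay, hydrogen in place of tert-butoxycarbonyl on the amine nitrogen of the six-membered non-aromatic ring with 1 nitrogen gives an at least 12-fold lower number from compound 1 to compound 3 (1.07 log units; beyond the scatter), the first sign that this position responds strongly to what it carries. The size of that step is only a lower bound, as compound 1 stands at a limit of the assay and not at a number: the limit of > 100000 nM in this assay, at which 1 of the 3 values shown sits.

With ((piperidin-4-yl)methyl)amino in place of 4-isopropylpiperazin-1-yl on an aromatic carbon, the reading gives a 1.7-fold lower number from compound 2 to compound 3 (0.22 log units; within the scatter), so these two groups cannot be told apart in this assay.

The compounds shown do not tell whether the large step needs the nitrogen to carry hydrogen or only needs tert-butoxycarbonyl to leave, which a methyl or an acetyl group on that nitrogen would begin to separate. Equally open, from the compounds shown here alone, is how a carboxylic acid or a longer chain at the same place would read.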